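The source may hold more compounds than are shown below. What is called first, only, known or untested is meant among the compounds shown, and "the series" means these compounds.

Measured compounds:
Compound 1, `CC(C)(C)OC(=O)NCCCCCN1C(Nc2ccc(-c3ccccc3)cc2)=Nc2ccccc2C1CC(=O)NCc1ccccc1`, with 88.5% in an assay on HEK293 cells for inhibition of Voltage-dependent T-type calcium channel subunit alpha-1G (Homo sapiens), tested at 10 uM; on this read-out higher numbers stand for more inhibition at the one concentration tested (going by the name of the read-out) and lower numbers for less inhibition.
Compound 2, `COC(=O)CC1c2ccccc2N=C(Nc2ccc(-c3ccccc3)cc2)N1CCCCCNC(=O)OC(C)(C)C`, with 88.5% in this assay.
Compound 3, `COC(=O)CC1c2ccccc2N=C(Nc2ccc(-c3ccccc3)cc2)N1CCCCCN`, with 84.1% in this assay.

Compound 3 gives the lowest of the three numbers in this assay, but its gaps to compound 1 and to compound 2 are both within the scatter, so the three compounds cannot be ordered on these figures. The step from compound 3 to compound 4, `NCCCCCN1C(Nc2ccc(-c3ccccc3)cc2)=Nc2ccccc2C1CC(=O)NCc1ccccc1`, is benzylamino in place of methoxy on a carbonyl carbon. The most direct reference is the reverse exchange between compound 1 and compound 2, where no change at the digits printed from compound 1 to compound 2 (within the scatter). The other measured step, a number 4.4 percentage points lower from compound 2 to compound 3 (within the scatter), shows that the free amine chain, which compound 4 also carries, did not move the number beyond the scatter either. Compound 4 is therefore expected to sit close to compound 3, with a number 1.9 percentage points higher from compound 3 to compound 4 (within the scatter) as the estimated step, and no change beyond the scatter. The estimate for compound 4 is 86%, in a range from 78% to 93%.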

Compound 4, a percentage reported as inhibition, at one concentration (the size of the read-out at that concentration, not a potency): 91.8%
Estimate against measurement, compound 4: 5.8 percentage points below; the range from low to high includes it.
By their numbers in this assay, from the lowest: compounds 3, 1, 2 and 4 (each within the scatter of the next).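

In this assay, benzylamino in place of methoxy on a carbonyl carbon can now be read on the core with the free amine as well as on the core with tert-butoxycarbonyl, and it gives a number 7.7 percentage points higher from compound 3 to compound 4 (within the scatter). Across the two cores, this exchange shows no difference that stands out from the scatter: the same change on two cores in this assay, no change at the digits printed (within the scatter) from compound 1 to compound 2 and a number 7.7 percentage points lower (within the scatter) from compound 4 to compound 3, 7.7 percentage points apart, within the scatter of two such steps. Hydrogen in place of tert-butoxycarbonyl on an amine nitrogen can likewise now be read with benzylamino on the carbonyl carbon, where it gives a number 3.3 percentage points higher from compound 1 to compound 4 (within the scatter), and the two readings of that change also agree within the scatter: the same change on two cores in this assay, a number 4.4 percentage points lower (within the scatter) from compound 2 to compound 3 and a number 3.3 percentage points higher (within the scatter) from compound 1 to compound 4, 7.7 percentage points apart, within the scatter of two such steps.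

The compounds shown leave open whether a carboxylic acid on this carbonyl carbon, or a shorter chain carrying the amine, would move the number beyond the scatter. With one concentration in this assay, any difference in potency among these four compounds also remains open.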